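A methylsulfanyl swap on the shared core of compound 2

The source may hold more compounds than are shown below. What is called first, only, known or untested is meant among the compounds shown, and "the series" means these compounds.

Of the compounds shown here, three have been tested in a functional assay on MCF7 cells (Homo sapiens) for inhibition, read by MTT assay, with a stated time of 72 h; a lower number here means a stronger inhibitor, a higher number a weaker inhibitor. Compound 1 `Cn1cc(CO)c(N)nc1=O` gives > 100000 nM, which is a limit of the assay and not a number. Compound 3 `Cc1cc(=O)[nH]c(=O)n1COC(CO)CO` gives > 100000 nM, again only a limit. Compound 2 `O=c1nc(NO)cc[nH]1` gives > 100000 nM, also a limit. Going by the values given here, compound 2 therefore stands nowhere apart from the others: all three values sit at the limit of > 100000 nM in this assay, at which 3 of the 3 values shown sit, and no step between any two of them can be read, since none of the three gives a number.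

The unmeasured compound 4 `CSc1cc[nH]c(=O)n1` differs from compound 2 in one place, methylsulfanyl in place of hydroxyamino on an aromatic carbon, next to the ring nitrogen and opposite the ring nitrogen of the six-membered aromatic ring with 2 nitrogen. Among the compounds with values here, because every measured value rests at the limit of > 100000 nM in this assay, at which 3 of the 3 values shown sit, there is no measured step on which a direction could be based, and no step beyond the scatter is expected in this assay.

Compound 4 is accordingly expected to give about 150000 nM in this assay, within a range from 50000 nM to 500000 nM, and most probably to be reported only as a limit. The expected step is a step that the limit leaves unreadable from compound 2 to compound 4, which is none beyond the scatter.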

Compound 4, half-maximal inhibitory concentration: > 100000 nM
Compound 4 gave a limit, no number; the forecaster's own chance of this, stated with the estimate: 85%; the middle value does not contradict the limit.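

The step between compound 2 and compound 4, methylsulfanyl in place of hydroxyamino on an aromatic carbon, cannot be read, since neither compound gives a number, only a limit: the limit of > 100000 nM in this assay, at which 4 of the 4 values shown sit.

The compounds shown leave open whether any change on the shared core of compound 2 would give a readable number at all.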